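A few compounds are considered here, and "the series" means these few. Any claim that something is new, unique, unknown or untested is made for them only; others in the source may bear on it.

Compound 2 `COc1ccc(Cn2c(CCc3ccccc3)nnc2[C@H](NC(=O)c2ccccn2)c2c[nH]c3ccccc23)cc1` holds the lowest of the two numbers measured in an in vitro assay on LLC-PK1 cells for displacement of a labelled ligand from growth hormone secretagogue receptor type 1 (Homo sapiens); on this read-out higher numbers stand for weaker inhibition and lower numbers for stronger inhibition: compound 2 gives 0.7 nM. Its nearest neighbour is compound 1 `CCc1ccc(Cn2c(CCc3ccccc3)nnc2[C@H](NC(=O)c2ccccn2)c2c[nH]c3ccccc23)cc1`, which in this assay gives 67 nM; that single swap, methoxy in place of ethyl on an aromatic carbon, produced a 96-fold lower number from compound 1 to compound 2 (1.98 log units; beyond the scatter). Compound 3 `COc1ccc(Cn2c(CCc3ccccc3)nnc2[C@H](NC(=O)Cc2ccccn2)c2c[nH]c3ccccc23)cc1` has not yet been measured. It differs from compound 2 in one place: (pyridin-2-yl)methyl in place of pyridin-2-yl on a carbonyl carbon. Going by the values given here, no measured step touches this part of the shared core; the only step in hand concerns a different position, so it offers no guide to the size or direction of the change at the carbonyl carbon. With nothing to build on, the expectation is a step of about a 2.9-fold higher number from compound 2 to compound 3 (0.46 log units; beyond the scatter) in this assay, leaning slightly toward a higher number. Compound 3 is therefore estimated at 2 nM, with a range from 0.5 nM to 8 nM.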

Compound 3, half-maximal inhibitory concentration: 3 nM
Estimate against measurement, compound 3: 1.5-fold (0.18 log units) below; low and high end bracket the measured number.
By their numbers in this assay, from the lowest: compound 2; then compound 3; then compound 1.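

Going by these compounds alone, this carbonyl carbon is the first position seen to change the number other than through the methoxy-for-ethyl swap: putting (pyridin-2-yl)methyl in place of pyridin-2-yl gives a 4.3-fold higher number from compound 2 to compound 3 (0.63 log units; beyond the scatter) in this assay. The step is beyond the usual scatter and points toward weaker inhibition, yet it is rated modest, and compound 3 still gives 3 nM, so the inserted carbon does not cost the low number. No supporting measurement explains why this change moves the number.

Going by these compounds, whether a longer chain such as (pyridin-2-yl)ethyl would raise the number further, or whether phenyl in place of pyridin-2-yl would change it, remains open. Also open, on these data alone, is whether the same step would appear with ethyl rather than methoxy on the aromatic carbon.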